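The source may hold more compounds than are shown below. What is called first, only, known or untested is meant among the compounds shown, and "the series" means these compounds.

Measured compounds:
Compound 1, `O=C1N/C(=N/c2csc(-c3ccc(Cl)cc3)c2)S/C1=C\c1ccccc1`: 18000 nM in a functional assay on MDA-MB-231 cells (Homo sapiens) for cytotoxicity, read by MTT assay, with a stated time of 72 h; on this read-out higher numbers stand for weaker inhibition and lower numbers for stronger inhibition
Compound 2, `Cc1ccc(/C=C2\S/C(=N\c3csc(-c4ccc(Cl)cc4)c3)NC2=O)cc1`: 900 nM
Compound 3, `COc1cccc(N2C(=O)CS/C2=N\c2csc(-c3ccccc3)c2)c1`: "not determined" (no result reported)

Compound 1 and compound 2 differ in one place, (methyl in place of hydrogen on an aromatic carbon), and that change gave a 20-fold lower number from compound 1 to compound 2 (1.30 log units; beyond the scatter). Compound 4, `COc1cccc(N2C(=O)CS/C2=N\c2csc(-c3ccc(C)cc3)c2)c1`, differs from compound 3 by the same change, (methyl in place of hydrogen on an aromatic carbon), at the same place on the ring. The difference between the core of compound 1 and the core of compound 3 is not broken down here, and compound 3 itself carries no number in this assay, so nothing ties the two pairs together beyond the shared change. The step from compound 3 to compound 4 is therefore expected to be of the same kind as the earlier one, but its size cannot be read from a starting value. Compound 2, at 900 nM, is the closest measured anchor. Compound 4 is expected to fall near 3000 nM, within 500 nM to 20000 nM.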

Compound 4, half-maximal inhibitory concentration: > 50000 nM
Compound 4 gave a limit, no number; the forecaster's own chance of this, stated with the estimate: 20%; at least 16-fold (1.22 log units) between middle value and limit.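

In this assay compound 4 gives > 50000 nM, which is a limit and not a number. Among the compounds shown here, compound 3 has no number to set against it, so no step from compound 3 to compound 4 can be read. As far as these compounds go, whether the change from phenyl to 4-methylphenyl shifts the read-out on the core of compound 3 stays open.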